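Bromo to trifluoromethyl on the aniline ring of a urea series

The source may hold more compounds than are shown below. What is called first, only, known or untested is meant among the compounds shown, and "the series" means these compounds.

compound 1 `COc1cc(NC(=O)Nc2cc(Nc3cc(C(F)(F)F)ccc3OC)ncn2)cc(OC)c1`: 81.1%
compound 2 `COc1ccc(Br)cc1Nc1cc(NC(=O)Nc2c(Cl)cccc2Cl)ncn1`: 69%

In a functional assay on PC-9 cells (Homo sapiens) for inhibition, read by MTT assay, with a stated time of 48 h, tested at 10 uM (on this read-out higher numbers stand for more inhibition at the one concentration tested (going by the name of the read-out) and lower numbers for less inhibition), compound 2 gives 69%, the lower of the two numbers; compound 1, which carries a trifluoromethyl group, gives 81.1%, a gap beyond the usual scatter. Compound 3 `COc1ccc(C(F)(F)F)cc1Nc1cc(NC(=O)Nc2c(Cl)cccc2Cl)ncn1` is not yet measured. It differs from compound 2 by trifluoromethyl in place of bromo on an aromatic carbon. Going by the values given here, with no measured pair isolating this change, the step is expected to be small, perhaps a modest rise given that compound 1 with its trifluoromethyl group gives 81.1%, but likely within scatter: a number 4 percentage points higher from compound 2 to compound 3 (within the scatter). Compound 3 is therefore estimated at 73%, in the range 56% to 86%.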

Compound 3, a percentage reported as inhibition, at one concentration (the size of the read-out at that concentration, not a potency): 89%
Beside the measured number, compound 3's estimate is 16 percentage points below it; the measured number lies above the stated range.
By their numbers in this assay, from the lowest: compound 2; then compounds 1 and 3 (each within the scatter of the next).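

In this assay, trifluoromethyl in place of bromo, para to a methoxy group, now has a measured pair of its own, giving a number 20 percentage points higher from compound 2 to compound 3 (beyond the scatter). With trifluoromethyl held fixed, 2,6-dichlorophenyl in place of 3,5-dimethoxyphenyl on an amide-type nitrogen gives a number 7.9 percentage points higher from compound 1 to compound 3 (within the scatter), so that exchange separates the two compounds by no more than the usual scatter. Nothing measured here bears on the reason for the rise with trifluoromethyl.

Going by these compounds, how a nitrile, an amine or a methyl at this position would compare stays open. So does whether the bromo to trifluoromethyl step holds with 3,5-dimethoxyphenyl on the amide-type nitrogen.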